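Amino for Chloro on the Fused Ring of Compound 2

The source may report more compounds than this note shows. Statements on the series, on what has been measured and on what is new or still open speak of the compounds shown alone.

Measured compounds:
compound 1, `Nc1nn(C(=O)Nc2ccc(Cc3ccccc3)cc2)c2ccccc12`, 4660 nM
compound 2, `Nc1nn(C(=O)Nc2ccc(Cc3ccccc3)cc2)c2ccc(Cl)cc12`, 13000 nM

Both compounds were tested in a functional assay on SF-268 cells (Homo sapiens) for antiproliferative activity, read by sulforhodamine B assay, with a stated time of 48 h; on this read-out lower numbers stand for stronger inhibition of growth and higher numbers for weaker inhibition of growth. Compound 1 gives 4660 nM. Compound 2 gives 13000 nM, which is the highest of the two numbers; its nearest neighbour is compound 1, reached by a 2.8-fold higher number from compound 1 to compound 2 (0.45 log units; beyond the scatter).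

Compound 3, `Nc1ccc2c(c1)c(N)nn2C(=O)Nc1ccc(Cc2ccccc2)cc1`, has not yet been measured. It differs from compound 2 by amino in place of chloro on an aromatic carbon. Among the measured compounds shown here, the only measured step that bears on this position is a 2.8-fold higher number from compound 1 to compound 2 (0.45 log units; beyond the scatter), which shows that putting a chloro there in place of hydrogen raised the number by a modest but real amount. Nothing measured shows what an amino at the same place does, so the direction of the step from compound 2 to compound 3 rests on that single comparison. Since the chloro of compound 2 is removed, it is expected that the number falls back part of the way toward compound 1, with a 1.9-fold lower number from compound 2 to compound 3 (0.27 log units; within the scatter), though a step within the scatter is also possible. Compound 3 is therefore estimated at 7000 nM, with a range from 2500 nM to 20000 nM.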

Compound 3, concentration for 50% growth inhibition: 13000 nM
Beside the measured number, compound 3's estimate is 1.9-fold (0.27 log units) below it, and the stated range covers the measured number.
By their numbers in this assay, from the lowest: compound 1; then compounds 2 and 3 (each within the scatter of the next).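

In this assay, amino in place of chloro on this aromatic carbon gives no change at the digits printed from compound 2 to compound 3 (within the scatter) and so leaves the two groups indistinguishable at this position. Amino in place of hydrogen gives a 2.8-fold higher number from compound 1 to compound 3 (0.45 log units; beyond the scatter) at the same place, a step printed at the same size as a 2.8-fold higher number from compound 1 to compound 2 (0.45 log units; beyond the scatter) for chloro in place of hydrogen. What the earlier pair showed for chloro alone therefore now holds for a second group: across these three compounds, with none going against it, both groups at this place, meta to a fused ring and para to a fused ring, stand with a higher number than hydrogen, even though amino brings a hydrogen-bond donor and a hydrogen-bond acceptor by the count and chloro brings neither.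

No evidence is available that bears on this result. Open, as far as these compounds go, is whether the same step holds for other groups at this place, such as a methoxy group, a carboxylic acid or a fluorine atom, or whether any such group would bring the number back toward that of the hydrogen compound.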